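Benzylamide series: hydroxyl in place of terminal methyl

The compounds below may be only part of what the source reports. "The series", "measured", "known", "first", "only" and "open" are said of these compounds alone.

Two benzylamides have been measured so far. Compound 1 `CCC[C@H](N)C(=O)NCc1ccccc1` bears a 1-aminobutyl group on the carbonyl carbon. In a functional assay on the whole organism (strain NMRI) with Mus musculus as the target, with a stated time of 30 min (on this read-out higher numbers stand for an effect only at larger amounts of compound and lower numbers for an effect already at smaller amounts), compound 1 gives > 210 mg/kg, a limit of the assay and not a number. Compound 2 `CCC(C)C(N)C(=O)NCc1ccccc1` is the other measured member. In this assay compound 2 gives > 120 mg/kg, again a limit and not a number. Where compound 1 stands is therefore open: the two values sit at the limit of > 210 mg/kg in this assay, at which 1 of the 2 values shown sits, and at the limit of > 120 mg/kg in this assay, at which 1 of the 2 values shown sits, no step between measured compounds can be drawn, and no change beyond the scatter can be read from them.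

Compound 3 `N[C@H](CCO)C(=O)NCc1ccccc1` is not yet measured. Against compound 1 the change is 1-amino-3-hydroxypropyl in place of 1-aminobutyl on a carbonyl carbon. Within the data shown here, no measured step bears on this change in this assay. Among the measured compounds shown here, the only anchor is compound 1, whose value in this assay is a limit. The step of an at least 1.0-fold lower number from compound 1 to compound 3 (0.02 log units; that floor lies within the scatter) is expected to be none beyond the scatter. Compound 3 is estimated at 200 mg/kg, with a range from 100 mg/kg to 400 mg/kg, and most likely it is reported once more as a limit.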

Compound 3, dose for half-maximal effect: > 120 mg/kg
Compound 3: no number, only a limit (the forecaster's own chance of this, stated with the estimate: 70%); the middle value lies beyond the limit too.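

Among these compounds, compound 1 and compound 3 both stand as limits and not numbers in this assay, and no step between them can be read. The compounds shown leave open whether 1-amino-3-hydroxypropyl in place of 1-aminobutyl on a carbonyl carbon changes the read-out at all, and in which direction, as none of them yet gives a number.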